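Methyl for hydrogen on the amide-bearing ring of compound 1

The compounds below may be only part of what the source reports. "The series", "measured", "known", "first", "only" and "open" are said of these compounds alone.

Two members of this series have been run so far. Compound 1 `CN1C[C@@H](COc2ccc(C(=O)Nc3cccc(CC(=O)O)c3)c(Cl)c2)Oc2ccccc21` carries a chloro group on its benzamide ring and an unsubstituted carboxymethylphenyl amide; in an assay on CHO cells for displacement of a labelled ligand from prostaglandin D2 receptor (Mus musculus), read by scintillation counting, with a stated time of 60 min (a lower number here means a stronger inhibitor, a higher number a weaker inhibitor), compound 1 gives 16 nM. Compound 2 `Cc1cc(OC[C@@H]2CN(C)c3ccccc3O2)ccc1C(=O)Nc1cc(F)cc(CC(=O)O)c1` differs from it in more than one place, with a methyl group in place of the chloro and a fluoro on the acid-bearing ring; in this assay compound 2 gives 7.4 nM. Of these two numbers compound 1 holds the higher one, and its gap to compound 2 lies beyond the scatter, though the several simultaneous changes between them allow no single-point reading.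

Compound 3 `Cc1ccc(CC(=O)O)cc1NC(=O)c1ccc(OC[C@@H]2CN(C)c3ccccc3O2)cc1Cl` is the next case, awaiting its result in this assay. Relative to compound 1 the change is methyl in place of hydrogen on an aromatic carbon, placed ortho to a large group and para to the carboxymethyl group. For the measured compounds named here, no single-change step of this kind is available among the measured pair, so the effect is open. Going by the values given here, with no comparable step to lean on, a step within the scatter is expected, a 1.3-fold lower number from compound 1 to compound 3 (0.12 log units; within the scatter), in either direction. Compound 3 is estimated at 12 nM, with a plausible range from 4 nM to 40 nM.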

Compound 3, inhibition constant: 26 nM
Compound 3: the middle estimate sits 2.2-fold (0.34 log units) below what was measured; low and high end bracket the measured number.
By their numbers in this assay, from the lowest: compound 2; then compounds 1 and 3 (each within the scatter of the next).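

In this assay, placing a methyl in place of hydrogen on this aromatic carbon, ortho to a large group and para to a carboxymethyl group, gives a 1.6-fold higher number from compound 1 to compound 3 (0.21 log units; within the scatter). For the compounds shown here, this is the first single-change step: the earlier pair differed in more than one place and could not isolate any one position, whereas this step isolates one carbon of the amide-bearing ring and shows that adding one carbon there produces no change distinguishable from the scatter. No available measurement bears on the reason for this result.

Going by these compounds alone, still open is whether an ethyl group, a methoxy group or an amine on the same carbon would also stay within the scatter of compound 1, since a single methyl gives only one reading at this position. Also open, going by these compounds, is whether the methyl would give a step of similar size on the background of compound 2, with its methyl on the benzamide ring and its fluoro on the acid-bearing ring.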